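The source may report more compounds than this note shows. Statements on the series, on what has been measured and on what is new or still open speak of the compounds shown alone.

Of the compounds shown here, two of a shared core have been measured in a functional assay on HT-29 cells (Homo sapiens) for cytotoxicity, read by MTT assay, with a stated time of 72 h; on this read-out lower numbers stand for stronger inhibition and higher numbers for weaker inhibition. Compound 1 `CN(C)CCCNc1nc(-c2ccc(NC(=O)Nc3ccc(Cl)cc3)cc2)nc2c(Cl)c(Cl)sc12` gives 330 nM in this assay, and compound 2 `CN(C)CCCNc1nc(-c2ccc(NC(=O)Nc3ccccc3Cl)cc2)nc2c(Cl)c(Cl)sc12` gives 820 nM. Among the measured compounds shown here, the only step between measured compounds runs from compound 1 to compound 2 a 2.5-fold higher number from compound 1 to compound 2 (0.40 log units; beyond the scatter). On the numbers shown, compound 2 stands highest of the two, with compound 1 as its nearest neighbour.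

Compound 3 `CN(C)CCNc1nc(-c2ccc(NC(=O)Nc3ccccc3Cl)cc2)nc2c(Cl)c(Cl)sc12` has not yet been measured in this assay. It differs from compound 2 by dimethylamino in place of (dimethylamino)methyl on a saturated chain carbon, two bonds along the chain from a nitrogen on an aromatic ring, a change on a saturated chain carbon, two bonds along the chain from a nitrogen on an aromatic ring. For the measured compounds named here, the one measured step concerned the chlorophenyl on the amide-type nitrogen, not this chain, so no step bears on the change from compound 2 to compound 3, and the data give no guidance on its direction.

For compound 3 the expected step from compound 2 is therefore no change at the digits printed from compound 2 to compound 3 (within the scatter), none beyond the scatter. Compound 3 is estimated at 820 nM in this assay, in a range from 330 nM to 2000 nM.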

Compound 3, half-maximal inhibitory concentration: 570 nM
Compound 3: the middle estimate sits 1.4-fold (0.16 log units) above what was measured, within the range that was stated.
By their numbers in this assay, from the lowest: compounds 1, 3 and 2 (each within the scatter of the next, the first and the last beyond it).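

In this assay, among the compounds shown here, the move from the 3-(dimethylamino)propyl chain of compound 2 to the 2-(dimethylamino)ethyl chain of compound 3 gives a 1.4-fold lower number from compound 2 to compound 3 (0.16 log units; within the scatter) and is the first reading at this position on a saturated chain carbon, two bonds along the chain from a nitrogen on an aromatic ring. With the 2-chlorophenyl group held in place, the two chain lengths cannot be told apart on this read-out, so this position accepts the change without a step beyond the scatter, whereas the earlier step at the chlorophenyl group did lie beyond it. Nothing available explains why these two chains read alike.

On these data alone, it remains open whether the 2-(dimethylamino)ethyl chain would read the same alongside the 4-chlorophenyl group of compound 1, since the chain has been compared only with the 2-chlorophenyl group in place. The compounds shown also leave open how a longer chain such as 4-(dimethylamino)butyl, or a different amine at the chain end such as morpholine or piperidine, would read in this assay at this position.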